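A few compounds are considered here, and "the series" means these few. Any claim that something is new, unique, unknown or untested is made for them only; others in the source may bear on it.

Three measured compounds share one core and differ only in the group on the carbonyl carbon. In an assay on SHEP1 cells for agonist activity at Neuronal acetylcholine receptor; alpha4/beta2 (Homo sapiens), read by FLIPR and calcium flux (on this read-out lower numbers stand for smaller maximal responses and higher numbers for larger maximal responses), compound 1 `C[C@@H]1C[C@@H]1C(=O)N1CC2CNCC2C1` gives 140%, compound 2 `O=C(C1CC1)[C@H]1C[C@H]2CNC[C@H]2C1` gives 120% and compound 3 `O=C(c1ccco1)[C@H]1C[C@H]2CNC[C@H]2C1` gives 94%, the lowest of the three numbers, with compound 2 nearest and compound 1 furthest. For the measured compounds named here, the only step with a direct bearing is a number 26 percentage points lower from compound 2 to compound 3 (beyond the scatter). Compound 4 `COC(=O)[C@H]1C[C@H]2CNC[C@H]2C1` differs from compound 3 by methoxy in place of furan-2-yl on a carbonyl carbon. Going by the values given here, the furan-2-yl that entered in the step to compound 3 leaves again, and a small acyclic group takes its place, so in this assay a modest recovery toward compound 2 is expected, though no measured step covers methoxy itself. Compound 4 is expected at 110%, between 80% and 140%, which would mean an expected step of a number 16 percentage points higher from compound 3 to compound 4 (beyond the scatter).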

Compound 4, largest response reached (Emax), in percent of the reference or control that the assay uses: 130%
Compound 4: middle estimate off by 20 percentage points, on the low side, and the stated range covers the measured number.
By their numbers in this assay, from the lowest: compound 3; then compounds 2, 4 and 1 (each within the scatter of the next, the first and the last beyond it).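

On the carbonyl carbon, methoxy in place of furan-2-yl gives a number 36 percentage points higher from compound 3 to compound 4 (beyond the scatter) in this assay, so a group with no ring restores a high maximal response. Methoxy in place of cyclopropyl gives a number 10 percentage points higher from compound 2 to compound 4 (within the scatter), so these two groups cannot be told apart here, and only furan-2-yl stands apart from them. Nothing available here explains these differences.

From the compounds shown here alone, whether an amine or ethoxy on this carbon keeps the response of compound 4 remains open. So does whether phenyl would behave like furan-2-yl.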